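Tert-Butyl in Place of Iodo: Expectation for Compound 4

The compounds below may be only part of what the source reports. "The series", "measured", "known", "first", "only" and "open" are said of these compounds alone.

Compound 1, `Nc1nc2ccc(I)cc2s1`, gives > 10 mg/kg in a functional assay on the whole organism with Rattus norvegicus as the target; a lower number here means that less compound is needed, a higher number that more compound is needed for the effect; this is a limit, not a number.
Compound 2, `CC(C)(C)Oc1ccc2nc(N)sc2c1`, gives > 10 mg/kg in this assay; this also is a limit.
Compound 3, `CCCc1ccc2nc(N)sc2c1`, gives 6 mg/kg in this assay.

Compound 1 therefore stands only at a limit, and so does one of the two other values shown, as the limit of > 10 mg/kg in this assay, at which 2 of the 3 values shown sit, records. Compound 4, `CC(C)(C)c1ccc2nc(N)sc2c1`, differs from compound 1 as follows: tert-butyl in place of iodo on an aromatic carbon.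

Of the measured steps, the closest is a step that the two limits leave unreadable from compound 1 to compound 2, whose size the two limits leave unreadable. The step of an at least 1.6-fold lower number from compound 1 to compound 3 (0.22 log units; that floor lies within the scatter) and the step of an at least 1.6-fold lower number from compound 2 to compound 3 (0.22 log units; that floor lies within the scatter) each show a floor that lies within the scatter. Given that compound 1 is a limit, the step in this assay to compound 4 cannot be read from these data with confidence; a move to a measurable number is expected, but no large one.

Compound 4 is therefore expected to give about 8 mg/kg, within 3 mg/kg to 20 mg/kg, which is an estimated step of an at least 1.2-fold lower number from compound 1 to compound 4 (0.09 log units; that floor lies within the scatter).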

Compound 4, dose for half-maximal effect: 4 mg/kg
For compound 4 the middle estimate is 2.0-fold (0.30 log units) above the measured one; low and high end bracket the measured number.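

In this assay, tert-butyl in place of iodo gives an at least 2.5-fold lower number from compound 1 to compound 4 (0.39 log units; beyond the scatter), the first floor in this set that lies beyond the scatter. Tert-butyl in place of tert-butoxy at the same position gives an at least 2.5-fold lower number from compound 2 to compound 4 (0.39 log units; beyond the scatter), so the two compounds with a carbon-linked alkyl group, compound 3 and compound 4, both give readable numbers, while iodo and tert-butoxy do not. Tert-butyl in place of propyl gives a 1.5-fold lower number from compound 3 to compound 4 (0.18 log units; within the scatter), so branching of the alkyl group shows no readable effect here.

How far each step truly reaches stays unknown, and the step between compound 1 and compound 2 cannot be read, since both of these compounds sit at a limit: the limit of > 10 mg/kg in this assay, at which 2 of the 4 values shown sit. How a longer chain such as hexyl, an amine or a carboxylic acid would behave at this position remains open.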